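The source may report more compounds than this note shows. Statements on the series, on what has been measured and on what is new or still open speak of the compounds shown alone.

Going by the values given here, in a functional assay on Caco-2 cells (Homo sapiens), read by MTT assay, with a stated time of 48 h (on this read-out higher numbers stand for weaker inhibition and lower numbers for stronger inhibition), compound 3 `CCn1c(C(=O)NCCN)ccc1C(CC)(CC)c1ccc(OCC(O)C(C)(C)C)c(C)c1` gives 1000 nM, the lowest of the three numbers measured so far. Compound 2 `CCN(CC)CCNC(=O)c1ccc(C(CC)(CC)c2ccc(OCC(O)C(C)(C)C)c(C)c2)n1CC` gives 2310 nM, and compound 1 `CCOC(=O)CN(C)C(=O)c1ccc(C(CC)(CC)c2ccc(OCC(O)C(C)(C)C)c(C)c2)n1CC` gives 12200 nM. The next compound, compound 4 `C#CC(C)OC(=O)c1ccc(C(CC)(CC)c2ccc(OCC(O)C(C)(C)C)c(C)c2)n1CC`, keeps the shared core and alters one group: (1-methylprop-2-yn-1-yl)oxy in place of (2-aminoethyl)amino on a carbonyl carbon. In words, (1-methylprop-2-yn-1-yl)oxy takes the place of (2-aminoethyl)amino on a carbonyl carbon.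

Among the compounds with values here, two measured steps bear on this change, as both alter the group on that same carbonyl carbon. The large one is a 12-fold lower number from compound 1 to compound 3 (1.09 log units; beyond the scatter), where (2-aminoethyl)amino replaces ((ethoxycarbonyl)methyl)(methyl)amino. The modest one is a 2.3-fold lower number from compound 2 to compound 3 (0.36 log units; beyond the scatter), where amino replaces diethylamino at the end of the chain. Compound 1 is the closest guide, since, like compound 4, it has no amino group at the end of a chain. Within the data shown here, its entering group still differs, and no measured compound carries the (1-methylprop-2-yn-1-yl)oxy group, so the range must stay wide.

In this assay, the expected change is an 8.0-fold higher number from compound 3 to compound 4 (0.90 log units; beyond the scatter), a move to a higher number that is beyond the scatter and close in size to the large step, though in the opposite direction. For compound 4 the estimated value is 8000 nM, within an expected range from 2500 nM to 25000 nM.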

Compound 4, half-maximal inhibitory concentration: > 50000 nM
Compound 4: a limit, no number; the forecaster's own chance of this, stated with the estimate: 10%; middle value at least 6.2-fold (0.79 log units) away from the limit.
By their numbers in this assay, from the lowest: compound 3; then compound 2; then compound 1. At a limit, above all of these: compound 4.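

In this assay, compound 4 gives no number, only a limit of the assay: the limit of > 50000 nM in this assay, at which 1 of the 4 values shown sits. Even so, the steps can be bounded: an at least 50-fold higher number from compound 3 to compound 4 (1.69 log units; beyond the scatter), an at least 21-fold higher number from compound 2 to compound 4 (1.33 log units; beyond the scatter), and an at least 4.0-fold higher number from compound 1 to compound 4 (0.61 log units; beyond the scatter). The earlier compounds shown here all hold a nitrogen on the carbonyl carbon and varied only the chain behind it, whereas this result shows that replacing that nitrogen-linked group with the oxygen-linked (1-methylprop-2-yn-1-yl)oxy group gives a higher number than any of the three, including compound 1, which until now had the highest.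

Compound 4 changes the atom on the carbonyl carbon and the chain at the same time, so the compounds shown cannot tell which of the two accounts for the rise, and its limit leaves the full size of each step unknown. A plain ethoxy group on the carbonyl carbon, or a (2-aminoethyl)oxy group that keeps the amine of compound 3 while holding oxygen in place of the amide nitrogen, would separate these two changes.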